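N-Methylation of the ring amine across two cores

This account rests on a few compounds, and the source may have more. Where it says the series, first, only, none or still open, it means among the compounds named here.

Compound 1 `C1=C(c2cccnc2)C[C@@H]2CNC[C@H]1C2` gives 0.1 nM in an in vitro assay on SH-EP1 cells for displacement of a labelled ligand from Neuronal acetylcholine receptor; alpha4/beta2 (Homo sapiens); on this read-out higher numbers stand for weaker inhibition and lower numbers for stronger inhibition. For the measured compounds named here, compound 2 `CN1C[C@@H]2C=C(c3cccnc3)C[C@@H](C2)C1` carries the change methyl in place of hydrogen on an amine nitrogen in a ring and gives 9.4 nM; the step of a 94-fold higher number from compound 1 to compound 2 (1.97 log units; beyond the scatter) is the only measured step of this kind so far. Compound 3 `CC(C)Oc1cncc(C2=CC3CNCC(C2)C3)c1` stands on a different core; the difference between the two cores is not broken down here. Compound 3 gives 0.26 nM, a somewhat higher number than compound 1 and a much lower one than compound 2.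

Compound 4 `CC(C)Oc1cncc(C2=CC3CC(C2)CN(C)C3)c1` is not yet measured. It differs from compound 3 by methyl in place of hydrogen on an amine nitrogen in a ring, the same change that separates compound 2 from compound 1, at the same place on the ring. Going by the values given here, only the one earlier step shows what this change does, so the expectation rests on that step alone: a step of about a 96-fold higher number from compound 3 to compound 4 (1.98 log units; beyond the scatter) is expected from compound 3 to compound 4, because the step of a 94-fold higher number from compound 1 to compound 2 (1.97 log units; beyond the scatter) was large and the place is the same. Compound 4 is therefore estimated at 25 nM, with a plausible span from 6 nM to 100 nM; whether the second core carries the change the same way is the open question.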

Compound 4, inhibition constant: 2.2 nM
The estimate for compound 4 lay 11-fold (1.06 log units) above the measured number, and the stated range ends above it.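

In this assay, methyl in place of hydrogen on an amine nitrogen in a ring gives a higher number on both cores, but the size of the step does not carry over from one core to the other: the same change on two cores in this assay, a 94-fold higher number (1.97 log units; beyond the scatter) from compound 1 to compound 2 and an 8.5-fold higher number (0.93 log units; beyond the scatter) from compound 3 to compound 4, 11-fold (1.05 log units) apart, beyond the scatter of two such steps

The new step, an 8.5-fold higher number from compound 3 to compound 4 (0.93 log units; beyond the scatter), therefore supports carrying over the direction of the change to the core of compound 3, while the step from the core of compound 1 overstates its size there. For the compounds shown here, with only two pairs, this gives no rule for a further core, and it does not show which difference between the two cores goes with the smaller step.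

Going by these compounds, it remains open whether an ethyl group or a longer chain on the same amine nitrogen would widen the step on either core. On these data alone, it also remains open whether the gap between the two steps would persist with a fluorine atom or a nitrile on the pyridine ring in place of the group carried by compound 3 and compound 4.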